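Stretching the carbamate chain from allyl to octyl

This account rests on a few compounds, and the source may have more. Where it says the series, first, only, none or still open, it means among the compounds named here.

Compound 2 `C=CCOC(=O)NS(=O)(=O)Nc1cc(-c2cc3cc(F)ccc3[nH]2)ccc1OC` gives 540 nM in an assay for inhibition of Polyunsaturated fatty acid lipoxygenase ALOX15 (Oryctolagus cuniculus), read by spectrophotometry; a higher number here means a weaker inhibitor, a lower number a stronger inhibitor; the only companion measured, compound 1 `COc1ccc(-c2cc3cc(F)ccc3[nH]2)cc1NS(=O)(=O)NC(=O)OCC(C)C`, gives 420 nM, and the two numbers sit within the scatter of each other. Within the data shown here, the single step known at this position, a 1.3-fold higher number from compound 1 to compound 2 (0.11 log units; within the scatter), involved a small change of chain shape and barely moved the number. Compound 3 `CCCCCCCCOC(=O)NS(=O)(=O)Nc1cc(-c2cc3cc(F)ccc3[nH]2)ccc1OC` brings a much larger change: heptyl in place of vinyl on a saturated chain carbon bound to an oxygen next to a carbonyl group. With only that small, uninformative step to go on, the estimate is a step of a 1.1-fold higher number from compound 2 to compound 3 (0.05 log units; within the scatter), no clear direction expected. Compound 3 is therefore estimated at 600 nM, with a range from 200 nM to 2000 nM.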

Compound 3, half-maximal inhibitory concentration: 47 nM
The estimate for compound 3 lay 13-fold (1.11 log units) above the measured number; the whole stated range lies above it.
By their numbers in this assay, from the lowest: compound 3; then compounds 1 and 2 (each within the scatter of the next).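

In this assay this place on the carbamate chain proves far from indifferent: octyl in place of allyl gives an 11-fold lower number from compound 2 to compound 3 (1.06 log units; beyond the scatter) and octyl against the chain of compound 1 gives an 8.9-fold lower number from compound 1 to compound 3 (0.95 log units; beyond the scatter) in the same direction. The two shorter chains, within the scatter of each other, gave no hint of this. Nothing available explains the drop.

From the compounds shown here alone, whether chains of intermediate length share this effect, or whether a longer chain such as dodecyl would lower the number further, remains open. So does the outcome of ending the octyl chain in a carboxylic acid or an amine.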